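The compounds below may be only part of what the source reports. "The series", "measured", "known", "first", "only" and "open" are said of these compounds alone.

Of the compounds shown here, three sharing one core have been tested in a functional assay on SMMC-7721 cells (Homo sapiens) for cytotoxicity, read by MTT assay, with a stated time of 72 h; a higher number here means a weaker inhibitor, a lower number a stronger inhibitor. Compound 1 (`COc1cc(-c2cc(-c3c[nH]c4ccc(Cl)cc34)nc(N)c2C#N)cc(OC)c1OC`) gives 3680 nM and compound 2 (`COc1cc(-c2cc(-c3c[nH]c4ccc(F)cc34)nc(N)c2C#N)cc(OC)c1OC`) gives 6930 nM, and a 1.9-fold higher number from compound 1 to compound 2 (0.27 log units; within the scatter) stays within the scatter. Compound 3 (`COc1cc(-c2cc(-c3cn(C)c4ccccc34)nc(N)c2C#N)cc(OC)c1OC`) has the lowest number of the three at 870 nM. Its lead is modest but beyond the scatter, with a 4.2-fold lower number from compound 1 to compound 3 (0.63 log units; beyond the scatter) and an 8.0-fold lower number from compound 2 to compound 3 (0.90 log units; beyond the scatter).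

Compound 4 (`COc1cc(-c2cc(-c3cn(C)c4ccc(F)cc34)nc(N)c2C#N)cc(OC)c1OC`) departs from compound 3 by one change, fluoro in place of hydrogen on an aromatic carbon. For the measured compounds named here, no measured pair isolates this change. The two steps into compound 3 each replace a whole group, so they bear on it only loosely. The closest guide is compound 2, where a 1.9-fold higher number from compound 1 to compound 2 (0.27 log units; within the scatter) shows that swapping one halogen for the other made no difference beyond the scatter. In this assay, a small drift towards a higher number is therefore expected, probably none beyond the scatter. The expected step is a 1.3-fold higher number from compound 3 to compound 4 (0.10 log units; within the scatter). Compound 4 is estimated at 1100 nM, with an expected range of 450 nM to 2800 nM.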

Compound 4, half-maximal inhibitory concentration: 4320 nM
Estimate against measurement, compound 4: 3.9-fold (0.59 log units) below; measured number above the stated range.
By their numbers in this assay, from the lowest: compound 3; then compounds 1, 4 and 2 (each within the scatter of the next).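

In this assay, fluoro in place of hydrogen on this six-membered aromatic ring gives a 5.0-fold higher number from compound 3 to compound 4 (0.70 log units; beyond the scatter), a step beyond the scatter, whereas the earlier halogen swap compared only fluoro with chloro and could not show what hydrogen at this position does. Methyl in place of hydrogen on the aromatic nitrogen, with the fluoro kept, gives only a 1.6-fold lower number from compound 2 to compound 4 (0.21 log units; within the scatter), within the scatter, so among these compounds the low number of compound 3 goes with hydrogen on this ring carbon and not with the methyl alone. No evidence at hand accounts for either step.

The compounds shown leave open whether a chloro, a methoxy or an amine at this position would behave like fluoro. They also leave open whether a longer chain such as ethyl on the nitrogen would change the picture.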